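The source may report more compounds than this note shows. Statements on the series, on what has been measured and on what is new or still open speak of the compounds shown alone.

Measured compounds:
- compound 1 `Cc1cccc(S(=O)(=O)N[C@H]2C3CC[C@H](C3)[C@@H]2C/C=C\CCCC(=O)O)c1`: 1700 nM
- compound 2 `O=C(O)CCC/C=C\C[C@H]1[C@@H]2CCC(C2)[C@@H]1NS(=O)(=O)c1ccccc1`: 1000 nM; 7400 nM; 600 nM (3 entries)

Going by the values given here, in a functional assay (plasma) for inhibition, with Oryctolagus cuniculus as the target (on this read-out lower numbers stand for stronger inhibition and higher numbers for weaker inhibition), compound 1 gives 1700 nM, the only single number in this set; compound 2 has several entries, (the several entries of compound 2 in this assay, 1000 nM; 7400 nM; 600 nM (3 entries)), which spread beyond the usual scatter and so give no fixed reference. The unmeasured compound 3 `O=C(O)CCC/C=C\C[C@H]1[C@@H]2CCC(C2)[C@@H]1NS(=O)(=O)c1ccc(Cl)cc1` differs from compound 1 in one place: 4-chlorophenyl in place of 3-methylphenyl on a sulfonyl sulfur. Among the compounds with values here, no measured pair tells how this change acts, so its size cannot be judged from steps already seen. A modest step from compound 1 to compound 3, a 1.4-fold lower number from compound 1 to compound 3 (0.15 log units; within the scatter), is expected, within the scatter. For compound 3 the estimate in this assay is 1200 nM, with a range from 300 nM to 5000 nM.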

Compound 3, half-maximal inhibitory concentration: 300 nM
Beside the measured number, compound 3's estimate is 4.0-fold (0.60 log units) above it, and the stated range covers the measured number.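

At the sulfonyl sulfur, in this assay, the aryl group matters: 4-chlorophenyl in place of 3-methylphenyl gives a 5.7-fold lower number from compound 1 to compound 3 (0.75 log units; beyond the scatter). The two groups have the same heavy-atom count, so this position responds to a swap that leaves that count unchanged. Compound 2 offers no fixed reference for either group, as its entries spread widely: the several entries of compound 2 in this assay, 1000 nM; 7400 nM; 600 nM (3 entries)

The step changes the substituent and its place on the ring together, so it leaves open which of the two counts. A 4-methylphenyl or 3-chlorophenyl group would separate them.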